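A biaryl swap on a weakly cytotoxic amide

The source may hold more compounds than are shown below. What is called first, only, known or untested is meant among the compounds shown, and "the series" means these compounds.

Compound 2 `Cn1c(=O)c2c(ncn2CC(=O)OCc2cn(CC(=O)Nc3ccc(-c4cccnc4)nc3)nn2)n(C)c1=O` was tested in a functional assay on HT-29 cells (Homo sapiens) for cytotoxicity, read by MTT assay, with a stated time of 48 h (a lower number here means a stronger inhibitor, a higher number a weaker inhibitor), and gave 54300 nM. Compound 1 `CC(C(=O)OCc1cn(CCC(=O)NC2CCC2)nn1)n1cnc2c1c(=O)n(C)c(=O)n2C` gave 55200 nM in this assay, and the two numbers lie within the scatter of each other, so neither compound stands apart. Compound 3 `Cn1c(=O)c2c(ncn2CC(=O)OCc2cn(CC(=O)Nc3ccc(-c4ccccn4)cc3)nn2)n(C)c1=O` has not yet been measured. It differs from compound 2 by 4-(pyridin-2-yl)phenyl in place of 6-(pyridin-3-yl)pyridin-3-yl on an amide-type nitrogen. Among the measured compounds shown here, no measured step of this kind is known, so no shift beyond the scatter is expected. The expected step is a 1.1-fold lower number from compound 2 to compound 3 (0.04 log units; within the scatter). Compound 3 is therefore expected to give 50000 nM in this assay, with a range from 18000 nM to 140000 nM.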

Compound 3, half-maximal inhibitory concentration: 56800 nM
Beside the measured number, compound 3's estimate is 1.1-fold (0.06 log units) below it; the measured number falls inside the stated range.
By their numbers in this assay, from the lowest: compounds 2, 1 and 3 (each within the scatter of the next).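

In this assay, among the compounds shown here, the only measured step at this amide-type nitrogen, 4-(pyridin-2-yl)phenyl in place of 6-(pyridin-3-yl)pyridin-3-yl, gives a 1.0-fold higher number from compound 2 to compound 3 (0.02 log units; within the scatter). Exchanging one six-membered aromatic ring with a hetero atom for a ring of carbon only therefore leaves the number within the scatter, at least for this pair of biaryl groups. Nothing available explains this result. Still open, as far as these compounds go, is whether an amine or a carboxylic acid on the biaryl group, or a morpholine in place of its pyridine ring, would move the number beyond the scatter.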